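Replacing a saturated ring amine with an open benzylic amine

This account rests on a few compounds, and the source may have more. Where it says the series, first, only, none or still open, it means among the compounds named here.

Measured so far in an assay on CHO cells with 5-hydroxytryptamine receptor 1D (Homo sapiens) as the target; on this read-out lower numbers stand for stronger inhibition and higher numbers for weaker inhibition:
- compound 1, `OC1(CNCc2ccccc2)CCN(CCCc2c[nH]c3ccc(-n4cnnc4)cc23)CC1`, 0.45 nM
- compound 2, `Cc1ccccc1CNCC1(O)CCN(CCCc2c[nH]c3ccc(-n4cnnc4)cc23)CC1`, 4 nM
- compound 3, `CC1(C)CCCN(CC2(O)CCN(CCCc3c[nH]c4ccc(-n5cnnc5)cc34)CC2)C1`, 0.65 nM

Compound 3 sits second highest of the three numbers. It is close to compound 1, with a 1.4-fold higher number from compound 1 to compound 3 (0.16 log units; within the scatter), and clearly apart from compound 2, with a 6.2-fold lower number from compound 2 to compound 3 (0.79 log units; beyond the scatter).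

The unmeasured compound 4, `Cc1ccccc1CN(C)CC1(O)CCN(CCCc2c[nH]c3ccc(-n4cnnc4)cc23)CC1`, differs from compound 3 in one place: methyl(2-methylbenzyl)amino in place of 3,3-dimethylpiperidin-1-yl on a saturated chain carbon bound to a saturated ring carbon.

Within the data shown here, two measured steps bear on this. The step of a 6.2-fold lower number from compound 2 to compound 3 (0.79 log units; beyond the scatter) shows that swapping (2-methylbenzyl)amino for 3,3-dimethylpiperidin-1-yl at this position lowers the number; compound 4 runs that swap the other way, with an added methyl on the entering group. The step of an 8.9-fold higher number from compound 1 to compound 2 (0.95 log units; beyond the scatter) shows that the methyl on the aromatic carbon raised the number. Compound 4 carries that methyl too, so a rise beyond the scatter is expected, of modest size, roughly a 6.2-fold higher number from compound 3 to compound 4 (0.79 log units; beyond the scatter).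

Compound 4 is therefore estimated at 4 nM, within a range from 1.2 nM to 14 nM.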

Compound 4, half-maximal inhibitory concentration: 1.3 nM
Beside the measured number, compound 4's estimate is 3.1-fold (0.49 log units) above it; low and high end bracket the measured number.
By their numbers in this assay, from the lowest: compounds 1, 3 and 4 (each within the scatter of the next, the first and the last beyond it); then compound 2.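

Putting a methyl on the amine nitrogen gives a 3.1-fold lower number from compound 2 to compound 4 (0.49 log units; beyond the scatter) in this assay, so this nitrogen need not carry a hydrogen for a low number, and the open amine does better here with that methyl than without it. The open amine of compound 4 also comes close to the ring amine, with a 2.0-fold higher number from compound 3 to compound 4 (0.30 log units; within the scatter), a gap within the scatter, while the two added methyls together still leave a 2.9-fold higher number from compound 1 to compound 4 (0.46 log units; beyond the scatter), a gap beyond it. The compounds shown offer no evidence on why the nitrogen methyl has this effect.

Still open, on these data alone, is how methyl(benzyl)amino, with the nitrogen methyl but no methyl on the aromatic ring, would compare with compound 1. Also open, as far as these compounds go, is whether a larger group on that nitrogen, such as ethyl or isopropyl, would keep the number this low.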